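The source may report more compounds than this note shows. Statements on the series, on what has been measured and on what is new or still open speak of the compounds shown alone.

Measured compounds:
Compound 1, `CC(C)=CC[C@@H](OC(=O)c1ccco1)C1=CC(=O)c2c(O)ccc(O)c2C1=O`: 80300 nM
Compound 2, `CC(C)=CC[C@@H](OCC(C)O)C1=CC(=O)c2c(O)ccc(O)c2C1=O`: 24700 nM
Compound 3, `CC(C)=CC[C@@H](OC(=O)CC(C)(O)C(C)C)C1=CC(=O)c2c(O)ccc(O)c2C1=O`: 27700 nM

In a functional assay on HeLa cells (Homo sapiens) for cytotoxicity, read by MTT assay (on this read-out lower numbers stand for stronger inhibition and higher numbers for weaker inhibition), compound 1 gives the highest of the three numbers. Its nearest neighbour is compound 3, reached by a 2.9-fold lower number from compound 1 to compound 3 (0.46 log units; beyond the scatter); compound 2 sits furthest away, reached by a 3.3-fold lower number from compound 1 to compound 2 (0.51 log units; beyond the scatter). Between compound 2 and compound 3 the step is a 1.1-fold higher number from compound 2 to compound 3 (0.05 log units; within the scatter).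

Compound 4, `CC(C)=CC[C@@H](OC(=O)C1CCCCO1)C1=CC(=O)c2c(O)ccc(O)c2C1=O`, has not yet been measured. It differs from compound 1 in one place:

oxan-2-yl in place of furan-2-yl on a carbonyl carbon

Within the data shown here, the step that bears most directly on this change is the one from compound 1 to compound 3, where the furan-2-yl on the carbonyl carbon was also replaced, there by 2-hydroxy-2,3-dimethylbutyl, with a modest lowering of the number. The step to compound 2, which removes the (furan-2-yl)carbonyl altogether, also lowered the number modestly. Both replacements of the furan-2-yl in this series moved the number downward by a similar modest amount, so a modest step downward, or none beyond the scatter, is expected in this assay for compound 4.

For compound 4 the estimate in this assay is 50000 nM, with a range from 20000 nM to 130000 nM, which is expected to correspond to a 1.6-fold lower number from compound 1 to compound 4 (0.21 log units; within the scatter).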

Compound 4, half-maximal inhibitory concentration: > 100000 nM
Compound 4: only a limit was reported; the forecaster's own chance of this, stated with the estimate: 10%; at least 2.0-fold (0.30 log units) between middle value and limit.
By their numbers in this assay, from the lowest: compounds 2 and 3 (each within the scatter of the next); then compound 1. At a limit, above all of these: compound 4.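

In this assay, compound 4 is reported only as a limit, not as a number: the limit of > 100000 nM in this assay, at which 1 of the 4 values shown sits. Among these compounds, the oxan-2-yl in place of furan-2-yl gives an at least 1.2-fold higher number from compound 1 to compound 4 (0.09 log units; that floor lies within the scatter), so compound 4 cannot be placed firmly apart from compound 1, but this replacement brings none of the lowering of the number seen when the (furan-2-yl)carbonyl or its furan-2-yl was replaced in the earlier compounds, so replacing the furan-2-yl does not lower the number as a rule. The group on this carbonyl carbon therefore matters more than those earlier compounds suggested: oxan-2-yl in place of 2-hydroxy-2,3-dimethylbutyl gives an at least 3.6-fold higher number from compound 3 to compound 4 (0.55 log units; beyond the scatter), and (oxan-2-yl)carbonyl in place of 2-hydroxypropyl on the oxygen gives an at least 4.0-fold higher number from compound 2 to compound 4 (0.60 log units; beyond the scatter).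

As far as these compounds go, how far the true value of compound 4 lies beyond its limit remains open, and with it the full size of all three steps. Also open, from the compounds shown here alone, is whether ring size or the loss of the aromatic ring accounts for the difference from compound 1, a question that an oxolan-2-yl on the same carbonyl carbon would address, and whether a hydroxyl group on the oxan-2-yl ring would bring the number down towards those of compound 2 and compound 3.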